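The source may report more compounds than this note shows. Statements on the series, on what has been measured and on what is new or still open speak of the compounds shown alone.

Measured compounds in a physicochemical assay for solubility; a higher number here means a more soluble compound, a lower number a less soluble compound:
compound 1 `CCc1c(F)c(N2CC[C@H](N)C2)nc2c1c(=O)c(C(=O)O)cn2C1CC1`, 70 ug/mL
compound 2 `Cc1c(F)c(N2CC[C@H](N)C2)nc2c1c(=O)c(C(=O)O)cn2C1CC1`, 70 ug/mL
compound 3 `O=C(O)c1cn(C2CC2)c2nc(N3CC4CC3CN4)c(F)cc2c1=O`, 90 ug/mL

Compound 2 stands level with compound 1 in this assay, and compound 3 sits within the scatter of both at 90 ug/mL; the three numbers do not separate from one another. Among the measured compounds shown here, the only step between measured compounds, no change at the digits printed from compound 1 to compound 2 (within the scatter), alters a saturated chain carbon bound to an aromatic carbon and leaves the solubility where it was.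

Compound 4 `Cc1c(F)c(N2CC[C@H](N)C2)nc2c1c(=O)c(C(=O)O)cn2C(C)(C)C` has not been measured. It differs from compound 2 by tert-butyl in place of cyclopropyl on an aromatic nitrogen. For the measured compounds named here, no measured step touches the aromatic nitrogen: the step from compound 1 to compound 2 concerns a different part of the shared core, and the change from compound 2 to compound 3 swaps the amine-bearing ring, for which no single-point step exists, so only its two values can be compared, and they lie within the scatter. The present change therefore has no anchor among the measured steps. The step of a 1.8-fold lower number from compound 2 to compound 4 (0.24 log units; within the scatter) is expected to be modest and, if anything, downward, with a wide margin. Compound 4 is estimated at 40 ug/mL in this assay, with a range from 15 ug/mL to 110 ug/mL.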

Compound 4, solubility: 570 ug/mL
For compound 4 the middle estimate is 14-fold (1.15 log units) below the measured one; the whole stated range lies below it.
By their numbers in this assay, from the lowest: compounds 1, 2 and 3 (each within the scatter of the next); then compound 4.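

In this assay, among the compounds shown here, the group on the aromatic nitrogen is the first place where a single change gives a step beyond the scatter: tert-butyl in place of cyclopropyl gives an 8.1-fold higher number from compound 2 to compound 4 (0.91 log units; beyond the scatter), while the only earlier step, no change at the digits printed from compound 1 to compound 2 (within the scatter), changed a saturated chain carbon on the shared core. This position therefore responds to the exchange of a three-membered ring of carbon for tert-butyl, which has no ring, and the number moves upward, although a single step on one background establishes no general trend. Nothing available bears on the origin of this step, so it stands as an observation only.

Going by these compounds, it remains open whether the higher number follows from the loss of the ring or from the branching of tert-butyl, a question that an isopropyl or a cyclobutyl group on the same aromatic nitrogen would help to separate. On these data alone, it is also open whether tert-butyl has the same effect alongside the ethyl group of compound 1 or the amine-bearing ring of compound 3.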